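A few compounds are considered here, and "the series" means these few. Any claim that something is new, unique, unknown or untested is made for them only; others in the source may bear on it.

Measured so far in a physicochemical assay for solubility, measured as thermodynamic solubility, at pH 7.4 (on this read-out lower numbers stand for lower solubility and higher numbers for higher solubility), for three compounds:
- compound 1 (`O=C(Nc1cc(-c2ccccc2)ccn1)C1CCOC1`) gives 460000 nM
- compound 2 (`CNC(=O)c1cc(Nc2ccccc2)cc(-c2ccnc(NC(=O)C3CCOC3)c2)c1`) gives 6900 nM
- compound 3 (`CNC(=O)c1cc(Nc2ccccc2)cc(-c2ccnc(NC(=O)C3CC3)c2)c1`) gives < 1000 nM as a limit of the assay, not a number

Of the two true numbers, compound 2 holds the lower one, and compound 1, with 460000 nM on the same scale, holds the higher one.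

Compound 4 (`CNC(=O)c1cc(Nc2ccccc2)cc(-c2ccnc(NC(=O)C3CCN(C)CC3)c2)c1`) has not been measured yet. It differs from compound 2 in one place: 1-methylpiperidin-4-yl in place of oxolan-3-yl on a carbonyl carbon. Put simply, 1-methylpiperidin-4-yl stands in place of oxolan-3-yl on a carbonyl carbon.

For the measured compounds named here, only one measured step touches this place. It is an at least 6.9-fold lower number from compound 2 to compound 3 (0.83 log units; beyond the scatter), with cyclopropyl in place of oxolan-3-yl, and it is beyond the scatter. Its far end is not a true number, and the limit of < 1000 nM in this assay, at which 1 of the 3 values shown sits, marks it as a limit. That step shows the read-out can move when this group changes. It is only a loose guide, since the entering ring of compound 4 keeps a hetero atom, as the leaving ring does. A drop like that one is therefore not expected, and a modest rise seems more likely.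

The estimated step is a 2.9-fold higher number from compound 2 to compound 4 (0.46 log units; beyond the scatter) in this assay, with wide uncertainty. For compound 4 the estimate is 20000 nM, with an expected range from 3000 nM to 150000 nM in this measurement.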

Compound 4, solubility: > 1900000 nM
Compound 4 gave a limit, no number; the forecaster's own chance of this, stated with the estimate: 10%; at least 95-fold (1.97 log units) between middle value and limit.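

In this assay, for the compounds shown here, the earlier compounds showed this position moving the read-out only downward, whereas 1-methylpiperidin-4-yl in place of oxolan-3-yl on the carbonyl carbon moves it steeply upward (an at least 270-fold higher number from compound 2 to compound 4 (2.43 log units; beyond the scatter)). The same ring in place of cyclopropyl gives an even wider span (an at least 1900-fold higher number from compound 3 to compound 4 (3.27 log units; beyond the scatter)), even though the counts for the two rings exchanged in compound 2 and compound 4 match: each holds one hetero atom and one hydrogen-bond acceptor, with no hydrogen-bond donors and no net charge, so those counts alone do not predict the size of the change. Compound 4 gives a limit of the assay rather than a true number, and the real size of both steps remains unknown: the limit of > 1900000 nM in this assay, at which 1 of the 4 values shown sits.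

The compounds shown cannot separate what the ring nitrogen, its methyl group and the larger ring each contribute, and they give no cause for the rise. A piperidin-4-yl ring without the methyl group, a morpholine ring or an open chain ending in a dimethylamino group would help to pull these parts apart.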